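The compounds below may be only part of what the source reports. "The series", "measured", "known", "first", "only" and "open" are said of these compounds alone.

Measured so far in a functional assay on the whole organism (strain albino) for inhibition, with Rattus norvegicus as the target, read by paw edema, with stated times of 1 h and 4 h, at a dose of 200 mg/kg by the oral route; on this read-out lower numbers stand for less inhibition and higher numbers for more inhibition at the one dose given (going by the name of the read-out):
compound 1 `O=c1oc2ccccc2cc1C1=NN(c2ccccc2)[C@@H](/C=C/c2ccccc2)C1` gives 42.5%
compound 2 `CN(C)c1ccc([C@H]2CC(c3cc4ccccc4oc3=O)=NN2c2ccccc2)cc1` gives 40.1%

Compound 2 stands beside compound 1 with a gap within the scatter, so neither is set apart from the other. Compound 3 `COc1cccc([C@H]2CC(c3cc4ccccc4oc3=O)=NN2c2ccccc2)c1` differs from compound 2 in one place: 3-methoxyphenyl in place of 4-(dimethylamino)phenyl on a saturated ring carbon. Going by the values given here, the only step that bears on this is the one at the same saturated ring carbon, a number 2.4 percentage points lower from compound 1 to compound 2 (within the scatter), which lay within the scatter. On that basis no step beyond the scatter is expected for this assay, and the change from compound 2 to compound 3 is estimated at a number 0.1 percentage points lower from compound 2 to compound 3 (within the scatter). Compound 3 is therefore expected to give about 40%, within a range from 30% to 50%.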

Compound 3, a percentage reported as inhibition, in the whole organism at one dose (the size of the read-out at that dose, not a potency): 61.5%
Compound 3: the middle estimate sits 21.5 percentage points below what was measured; the whole stated range lies below it.
By their numbers in this assay, from the lowest: compounds 2 and 1 (each within the scatter of the next); then compound 3.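

In this assay the saturated ring carbon now proves able to move the read-out: 3-methoxyphenyl brings a number 21.4 percentage points higher from compound 2 to compound 3 (beyond the scatter) and a number 19 percentage points higher from compound 1 to compound 3 (beyond the scatter), where the earlier exchange at this carbon stayed within the scatter. The leaving 4-(dimethylamino)phenyl and the entering 3-methoxyphenyl have the same counts of hydrogen-bond donors and acceptors, so those counts do not separate them. Nothing available explains the rise.

On these data alone, whether it belongs to the methoxy group itself or to where that group sits on the phenyl ring stays open, as does how a 4-methoxyphenyl, 3-hydroxyphenyl or 3-chlorophenyl group would read at this carbon.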